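The source may hold more compounds than are shown below. What is called first, only, known or untested is meant among the compounds shown, and "the series" means these compounds.

Within the data shown here, compound 3, `CC(C)c1onc(-c2c(Cl)cccc2Cl)c1COc1ccc(N(C)Cc2ccc(OCC(=O)O)cc2)c(C(F)(F)F)n1`, gives 90% in an assay on isolated protein for agonist activity at Bile acid receptor (Homo sapiens), read by FRET (on this read-out higher numbers stand for larger maximal responses and lower numbers for smaller maximal responses), the lowest of the three numbers measured so far. Compound 1, `CC(C)c1onc(-c2c(Cl)cccc2Cl)c1COc1ccc(N(C)Cc2ccc(CCC(=O)O)cc2)c(C(F)(F)F)n1`, gives 96%, and compound 2, `CC(C)c1onc(-c2c(Cl)cccc2Cl)c1COc1ccc(N(C)Cc2cccc(C(=O)O)c2)c(C(F)(F)F)n1`, gives 102%; accordingly a number 6 percentage points lower from compound 1 to compound 3 (within the scatter), whereas a number 12 percentage points lower from compound 2 to compound 3 (beyond the scatter). Compound 4, `CC(C)c1onc(-c2c(Cl)cccc2Cl)c1COc1ccc(N(C)Cc2ccc(OCCO)cc2)c(C(F)(F)F)n1`, differs from compound 3 by hydroxymethyl in place of carboxy on a saturated chain carbon bound to an oxygen on an aromatic ring. Among the measured compounds shown here, no measured step exchanges carboxy for hydroxymethyl; the measured steps only shift the carboxy among 3-carboxyphenyl, 4-(2-carboxyethyl)phenyl and 4-(carboxymethoxy)phenyl, and all were small, as a number 6 percentage points higher from compound 1 to compound 2 (within the scatter) shows. With nothing measured to match this exchange, a modest downward step is expected for compound 4, a number 8 percentage points lower from compound 3 to compound 4 (within the scatter). The estimate for compound 4 in this assay is 82%, within a range from 60% to 100%.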

Compound 4, largest response reached (reported as efficacy), in percent of the reference or control that the assay uses: 87%
Estimate against measurement, compound 4: 5 percentage points below, within the range that was stated.
By their numbers in this assay, from the lowest: compounds 4, 3, 1 and 2 (each within the scatter of the next, the first and the last beyond it).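

Compound 4 is the first compound shown without a carboxy, and in this assay exchanging it for hydroxymethyl on the saturated chain carbon bound to an oxygen on an aromatic ring gives a number 3 percentage points lower from compound 3 to compound 4 (within the scatter), so in this compound a carboxy is not needed for a large maximal response. Measured against the other acids, the result is a number 9 percentage points lower from compound 1 to compound 4 (within the scatter) and a number 15 percentage points lower from compound 2 to compound 4 (beyond the scatter). Nothing available explains why the response holds after this exchange.

The compounds shown leave open whether an amine or a methyl ether at this place would hold the response. They also leave open whether a longer chain ending in a hydroxyl would do so.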